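The source may report more compounds than this note shows. Statements on the series, on what has been measured and on what is new or still open speak of the compounds shown alone.

Compound 1 `CCCCCCCCCCNC[C@@H]1OC[C@H](N)[C@@H]1O` and compound 2 `CCCCCCCCCCCNC[C@@H]1OC[C@H](N)[C@@H]1O` share the same core and differ only far out on a saturated chain. In a functional assay on A549 cells (Homo sapiens) for antiproliferative activity, read by MTT assay, with a stated time of 72 h (a higher number here means a weaker inhibitor, a lower number a stronger inhibitor), compound 1 gives 47800 nM and compound 2 gives 11100 nM, so compound 2 holds the lower of the two numbers and is the stronger inhibitor of this pair. For the measured compounds named here, the only measured step is a 4.3-fold lower number from compound 1 to compound 2 (0.63 log units; beyond the scatter), and it comes with methyl in place of hydrogen on a saturated chain carbon, ten or more bonds along the chain from an amine nitrogen.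

Compound 3 `CCCCCCCCCNC[C@@H]1OC[C@H](N)[C@@H]1O` moves the other way from compound 2: hydrogen in place of ethyl on a saturated chain carbon, nine bonds along the chain from an amine nitrogen. Here, hydrogen takes the place of ethyl on a saturated chain carbon, nine bonds along the chain from an amine nitrogen. Going by the values given here, the step to compound 2 is the only evidence, and a single step is thin support, but it points towards a higher number in this assay when the chain is cut back. Since ethyl is a larger piece than methyl, a larger step than a 4.3-fold lower number from compound 1 to compound 2 (0.63 log units; beyond the scatter) is expected, namely an 8.1-fold higher number from compound 2 to compound 3 (0.91 log units; beyond the scatter). For compound 3, the estimated value is 90000 nM, with an expected range from 45000 nM to 200000 nM.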

Compound 3, half-maximal inhibitory concentration: 22100 nM
The estimate for compound 3 lay 4.1-fold (0.61 log units) above the measured number; the measured number lies below the stated range.
By their numbers in this assay, from the lowest: compounds 2 and 3 (each within the scatter of the next); then compound 1.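

The step of a 2.0-fold higher number from compound 2 to compound 3 (0.30 log units; within the scatter) in this assay is within the scatter, so at this place on the chain, hydrogen in place of ethyl gives no change that can be read, and compound 2 and compound 3 cannot be ranked. The other new step is a 2.2-fold lower number from compound 1 to compound 3 (0.34 log units; beyond the scatter) and lies beyond the scatter: removing a methyl from the chain of compound 1 lowers the number, just as adding one did in the step of a 4.3-fold lower number from compound 1 to compound 2 (0.63 log units; beyond the scatter) seen earlier. Chain length therefore does not move the number in one steady direction across these compounds, since compound 1 goes against any such trend by standing above both of its neighbours, and nothing measured here accounts for this.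

The three compounds leave open whether a longer chain would bring the number down further, raise it again or leave it unchanged. They also leave open how a chain carrying a hydroxyl group, an amine or a phenyl ring would compare with these plain saturated chains on the shared core.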